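The source may report more compounds than this note shows. Statements on the series, on what has been measured and on what is new or still open speak of the compounds shown alone.

Measured so far:
- compound 1 `COc1cc(-c2nn(-c3cccc(NC(=O)Nc4cc(C(F)(F)F)cc(C(F)(F)F)c4)c3)cc2-c2ccncc2)ccc1Cl`: > 50000 nM
- compound 2 `COc1cc(-c2nn(-c3cccc(NC(=O)Nc4ccc(Cl)c(Cl)c4)c3)cc2-c2ccncc2)ccc1Cl`: 41200 nM
- compound 3 `O=C(Nc1cccc(-n2cc(-c3ccncc3)c(-c3ccc(Cl)c(O)c3)n2)c1)Nc1ccc(Cl)c(Cl)c1`: > 32500 nM

In a functional assay on M14 cells (Homo sapiens) for inhibition, read by sulforhodamine B assay, with a stated time of 48 h (on this read-out lower numbers stand for higher toxicity in this test and higher numbers for lower toxicity in this test), compound 1 gives only a limit, > 50000 nM. Compound 2 gives a number in this assay, 41200 nM. Compound 3 again gives only a limit, > 32500 nM. Compounds 2 and 3 differ in one place, (hydrogen in place of methyl on an oxygen on an aromatic ring), and the step between them, a step that the limit leaves unreadable from compound 2 to compound 3, cannot be given a size because compound 3 sits at the limit of > 32500 nM in this assay, at which 1 of the 3 values shown sits.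

Compound 4 `O=C(Nc1cccc(-n2cc(-c3ccncc3)c(-c3ccc(Cl)c(O)c3)n2)c1)Nc1cc(C(F)(F)F)cc(C(F)(F)F)c1` has not yet been measured. It differs from compound 1 by hydrogen in place of methyl on an oxygen on an aromatic ring, the same change as from compound 2 to compound 3, at the same place. The difference between the cores of compound 1 and compound 2 is not broken down here.

The step from compound 1 to compound 4 is expected to be a step that the limit leaves unreadable from compound 1 to compound 4, resting on compound 1 sitting at the limit of > 50000 nM in this assay, at which 1 of the 3 values shown sits, and on the unreadable step from compound 2 to compound 3. Compound 4 is therefore expected to show 60000 nM in this assay, between 30000 nM and 120000 nM, most likely reported again as a limit.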

Compound 4, concentration lethal to 50% of the cells: 6060 nM
Compound 4: middle estimate off by 9.9-fold (1.00 log units), on the high side, outside the stated range (below it).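

In this assay, the change from methoxy to hydroxy gives an at least 8.2-fold lower number from compound 1 to compound 4 (0.91 log units; beyond the scatter), a lower number that stands for higher toxicity in this test on the core that compound 1 and compound 4 share. The same change from compound 2 to compound 3 cannot be read, because compound 3 gives only a limit: the limit of > 32500 nM in this assay, at which 1 of the 4 values shown sits. On these data alone, this result therefore shows the change lowering the number on one core only and does not show that the change carries over to the other core, while the full size of the step also stays unknown, because compound 1 gives only a limit: the limit of > 50000 nM in this assay, at which 1 of the 4 values shown sits.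

The compounds shown leave open whether another group in place of the methoxy, such as an amine, a carboxylic acid or a longer chain like ethoxy, would give a similar number. They also leave open how 4-chloro-3-hydroxyphenyl would behave on cores other than those of compound 3 and compound 4.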